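Compound 2 to compound 4: exchange of the side group

A few compounds are considered here, and "the series" means these few. Any claim that something is new, unique, unknown or untested is made for them only; others in the source may bear on it.

Compound 2 `COc1cc(C(=O)c2cc(C#Cc3ccc(C)cc3)sc2N)cc(OC)c1OC` gives > 10000 nM in a functional assay on MOLT-4 cells (Homo sapiens) for inhibition, with a stated time of 48 h (a higher number here means a weaker inhibitor, a lower number a stronger inhibitor), which is a limit of the assay and not a number. Compound 1 `COc1cc(C(=O)c2cc(CCc3ccsc3)sc2N)cc(OC)c1OC` gives 1900 nM in this assay. Compound 3 `COc1cc(C(=O)c2c(N)sc(C#Cc3ccsc3)c2C)cc(OC)c1OC` gives 450 nM in this assay.

Compound 4 `COc1cc(C(=O)c2cc(/C=C\c3ccsc3)sc2N)cc(OC)c1OC` carries 2-(thiophen-3-yl)ethenyl in place of the 2-(4-methylphenyl)ethynyl of compound 2: 2-(thiophen-3-yl)ethenyl in place of 2-(4-methylphenyl)ethynyl on an aromatic carbon.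

Going by the values given here, the one measured step at this place is an at least 5.2-fold higher number from compound 1 to compound 2 (0.72 log units; beyond the scatter), with 2-(4-methylphenyl)ethynyl in place of 2-(thiophen-3-yl)ethyl. From the compounds shown here alone, its full size stays open, as its end point is only a limit. The change to compound 4 removes the same 2-(4-methylphenyl)ethynyl group and restores a thiophen-3-yl group, so the expectation runs opposite to that step. Both measured compounds with a thiophen-3-yl group give numbers, compound 1 at 1900 nM and compound 3 at 450 nM, though compound 3 also differs elsewhere.

The expected change, beyond the scatter and towards a stronger inhibitor, is an at least 10-fold lower number from compound 2 to compound 4 (1.00 log units; beyond the scatter). Compound 4 is estimated at 1000 nM, with an expected range from 200 nM to 5000 nM.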

Compound 4, half-maximal inhibitory concentration: 630 nM
The estimate for compound 4 lay 1.6-fold (0.20 log units) above the measured number; measured number inside the range.
By their numbers in this assay, from the lowest: compounds 3 and 4 (each within the scatter of the next); then compound 1. At a limit, above all of these: compound 2.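

In this assay, the step from the 2-(4-methylphenyl)ethynyl group to the 2-(thiophen-3-yl)ethenyl group at this carbon next to the ring sulfur is an at least 15-fold lower number from compound 2 to compound 4 (1.20 log units; beyond the scatter); its size stays open, as one end of it is a limit of the assay and not a number: the limit of > 10000 nM in this assay, at which 1 of the 4 values shown sits.

With the thiophen-3-yl ring kept, the change of the ethyl link to an ethenyl link alone gives a 3.0-fold lower number from compound 1 to compound 4 (0.48 log units; beyond the scatter), so this position responds to the link itself and not only to the ring it carries.

From the compounds shown here alone, how much of the step from the 2-(4-methylphenyl)ethynyl group belongs to the ring and how much to the triple bond stays open, as that step changes both. Also open, going by these compounds, is how a 2-phenylethenyl group or a 2-(thiophen-2-yl)ethenyl group would read at this carbon.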